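A Methoxy Added to the Benzyl Amide of Compound 2

The source may report more compounds than this note shows. Statements on the series, on what has been measured and on what is new or still open speak of the compounds shown alone.

Compound 2 `COc1ccc2c(=O)c(/C=C/C(=O)NCc3ccccc3)coc2c1` is one of three amides on a shared core. In a functional assay on Huh-7 cells (Homo sapiens) for inhibition, read by MTT assay, with a stated time of 48 h (a lower number here means a stronger inhibitor, a higher number a weaker inhibitor), compound 2 gives 13600 nM. Among the measured compounds shown here, compound 3 `COc1ccc2c(=O)c(/C=C/C(=O)Nc3cc(C)ccc3C)coc2c1` gives 11100 nM in this assay, and the step of a 1.2-fold lower number from compound 2 to compound 3 (0.09 log units; within the scatter) is within the scatter, so the two stand together as the only numbers reported. Compound 1 `COc1ccc2c(=O)c(/C=C/C(=O)Nc3cccc(Cl)c3)coc2c1` reaches only a limit, > 100000 nM (the limit of > 100000 nM in this assay, at which 1 of the 3 values shown sits). From compound 1 the steps of an at least 7.3-fold lower number from compound 1 to compound 2 (0.86 log units; beyond the scatter) and an at least 9.0-fold lower number from compound 1 to compound 3 (0.95 log units; beyond the scatter) are beyond the scatter. Compound 4 `COc1ccc(CNC(=O)/C=C/c2coc3cc(OC)ccc3c2=O)cc1` differs from compound 2 by methoxy in place of hydrogen on an aromatic carbon, benzyl to 4-methoxybenzyl. For the measured compounds named here, no measured step adds a methoxy: each swaps the whole group on the amide-type nitrogen, so none bears directly on this change. Compound 4 is therefore expected to show a step of a 1.0-fold lower number from compound 2 to compound 4 (0.02 log units; within the scatter), not beyond the scatter. Compound 4 is estimated at 13000 nM, within 5000 nM to 35000 nM.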

Compound 4, half-maximal inhibitory concentration: 7570 nM
Beside the measured number, compound 4's estimate is 1.7-fold (0.23 log units) above it; the measured number falls inside the stated range.
By their numbers in this assay, from the lowest: compounds 4, 3 and 2 (each within the scatter of the next). At a limit, above all of these: compound 1.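

In this assay the methoxy on the benzyl group gives a 1.8-fold lower number from compound 2 to compound 4 (0.25 log units; within the scatter) and so shows that this position takes the group with no change beyond the scatter. The step of a 1.5-fold lower number from compound 3 to compound 4 (0.17 log units; within the scatter) keeps these amides together, while an at least 13-fold lower number from compound 1 to compound 4 (1.12 log units; beyond the scatter) is large. That last step is only a bound, and compound 1 stands at a limit: the limit of > 100000 nM in this assay, at which 1 of the 4 values shown sits.

On these data alone, whether a hydroxyl, an amine or a carboxylic acid at this position would move the number beyond the scatter stays open, as does the effect of a methoxy elsewhere on the benzyl ring.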